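Working notes on four analogues of a shared core

The source may report more compounds than this note shows. Statements on the series, on what has been measured and on what is new or still open speak of the compounds shown alone.

Compound 1 `O=C(Nn1c(-c2cccc([N+](=O)[O-])c2)nc2c(-c3ccco3)n[nH]c2c1=O)c1cccnc1` gives 1.66% in a functional assay on DU-145 cells (Homo sapiens) for cytotoxicity, read by sulforhodamine B assay, with a stated time of 2 days, tested at 100 uM; a lower number here means less inhibition, a higher number more inhibition at the concentration tested (going by the name of the read-out). Compound 2 `O=C(Nn1c(-c2cccc([N+](=O)[O-])c2)nc2c(CCc3ccccc3)n[nH]c2c1=O)c1cccnc1` gives 22.5% in this assay, and compound 3 `O=C(Nn1c(-c2cccc([N+](=O)[O-])c2)nc2c(-c3ccco3)n[nH]c2c1=O)c1ccccc1` gives 16.1% in this assay. Compound 4 `O=C(Nn1c(-c2cccc([N+](=O)[O-])c2)nc2c(CCc3ccccc3)n[nH]c2c1=O)c1ccccc1` is not yet measured. The change phenethyl in place of furan-2-yl on an aromatic carbon occurs twice among these compounds; its measured instance gives a number 20.8 percentage points higher from compound 1 to compound 2 (beyond the scatter). The cores of compound 1 and compound 3 differ by phenyl in place of pyridin-3-yl on a carbonyl carbon, a change that gives a number 14.4 percentage points higher from compound 1 to compound 3 (beyond the scatter). Compound 4 arises from compound 3 by the same change, (phenethyl in place of furan-2-yl on an aromatic carbon); the surroundings of the place are described identically, so it is the same change, not merely the same kind. Among the compounds with values here, compound 4 is expected to sit a number 15.9 percentage points higher from compound 3 to compound 4 (beyond the scatter) in this assay, resting on the single earlier instance a number 20.8 percentage points higher from compound 1 to compound 2 (beyond the scatter) while allowing that one instance need not repeat in full. Compound 4 is estimated at 32%, between 15% and 50%.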

Compound 4, a percentage reported as inhibition, at one concentration (the size of the read-out at that concentration, not a potency): 92.5%
Beside the measured number, compound 4's estimate is 60.5 percentage points below it; the measured number lies above the stated range.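

Phenethyl in place of furan-2-yl gives a number 76.4 percentage points higher from compound 3 to compound 4 (beyond the scatter) in this assay, so this change keeps its direction but not its size when carried to the second core: the same change on two cores in this assay, a number 20.8 percentage points higher (beyond the scatter) from compound 1 to compound 2 and a number 76.4 percentage points higher (beyond the scatter) from compound 3 to compound 4, 55.6 percentage points apart, beyond the scatter of two such steps. Phenyl in place of pyridin-3-yl gives a number 70 percentage points higher from compound 2 to compound 4 (beyond the scatter), and it behaves in the same way: the same change on two cores in this assay, a number 14.4 percentage points higher (beyond the scatter) from compound 1 to compound 3 and a number 70 percentage points higher (beyond the scatter) from compound 2 to compound 4, 55.6 percentage points apart, beyond the scatter of two such steps. In these four compounds, the size of each step differs with the group at the other place, so the two steps do not simply add, but a single pair for each change gives no general rule for the series.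

Still open, from the compounds shown here alone, is whether this holds for other groups on the aromatic carbon, such as a longer chain or an amine. The same question applies on the carbonyl carbon, for example with a pyridin-4-yl group.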